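Geometry change from compound 1 to compound 3

The compounds below may be only part of what the source reports. "The series", "measured", "known", "first", "only" and "open" are said of these compounds alone.

Among the compounds with values here, compound 1 `C=C/C(C)=C\C=C\C(C)CC(=O)CC(C)C` holds the only numerical value in the set: in a functional assay on P388 cells (Mus musculus) for cytotoxicity (a lower number here means a stronger inhibitor, a higher number a weaker inhibitor), compound 1 gives 2.5 ug/mL. Compound 2 `CC(C)=C/C=C\C(C)/C=C/C=C(\C)C=O` reaches only a limit, (the limit of > 10 ug/mL in this assay, at which 1 of the 2 values shown sits); in this assay compound 2 gives > 10 ug/mL. Compound 3 `C=C/C(C)=C/C=C/C(C)CC(=O)CC(C)C` is not yet measured. It differs from compound 1 by the two compounds have the same atoms and bonds; at least one stereo element is drawn with a configuration in one of them and without one in the other: 1 of 3 stereo elements differ; a double bond is drawn Z in compound 1 and E in compound 3. Within the data shown here, no measured step between two compounds is available here, so the size of the step in this assay is open; a change of configuration at one double bond is expected to shift the value little, possibly not beyond the scatter. Compound 3 is estimated at 3 ug/mL, within 1 ug/mL to 10 ug/mL. The expected step is a 1.2-fold higher number from compound 1 to compound 3 (0.08 log units; within the scatter).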

Compound 3, half-maximal inhibitory concentration: 2.5 ug/mL
Compound 3: the middle estimate sits 1.2-fold (0.08 log units) above what was measured; low and high end bracket the measured number.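

Within the data shown here, the first measured step concerns the configuration at one double bond: in this assay there is no change at the digits printed from compound 1 to compound 3 (within the scatter). At this double bond, the Z and E drawings are therefore not told apart by this read-out. One caution applies to that reading: the fact that one of compounds 1 and 3 is drawn with a defined configuration and the other without, at the place where they differ

The compounds shown leave open what a carboxylic acid or an amine in place of the carbonyl would do in this assay. Also open, on these data alone, is whether the other stereo elements matter as little as this double bond.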